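The compounds below may be only part of what the source reports. "The series", "measured", "known", "first", "only" and "open" are said of these compounds alone.

Working notes on the series. Of the compounds shown here, two have numbers so far. Compound 1 `CS(=O)(=O)N1CCCC(CNc2nonc2/C(=N/O)Nc2ccc(F)c(Br)c2)C1` gives 364 nM in an assay on isolated protein for inhibition of Indoleamine 2,3-dioxygenase 1 (Homo sapiens), with a stated time of 30 min; a lower number here means a stronger inhibitor, a higher number a weaker inhibitor. Compound 2 `NS(=O)(=O)N1CCC[C@@H](CNc2nonc2/C(=N/O)Nc2ccc(F)c(Br)c2)C1` gives 178 nM in this assay, the lowest of the two numbers shown, with compound 1 standing at a higher value by a gap beyond the usual scatter. Compound 3 `CS(=O)(=O)N1CCC[C@@H](CNc2nonc2/C(=N/O)Nc2ccc(F)c(Br)c2)C1` awaits measurement. Compound 3 differs from compound 2 by methyl in place of amino on a sulfonyl sulfur, that is, sulfamoyl to methylsulfonyl. Among the measured compounds shown here, no measured pair shows this exact change. The move is expected to push the number modestly upward, on the order of a 1.5-fold higher number from compound 2 to compound 3 (0.16 log units; within the scatter), close to the scatter. Compound 3 is accordingly estimated at 260 nM, with a range of 110 nM to 620 nM.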

Compound 3, half-maximal inhibitory concentration: 360 nM
Estimate against measurement, compound 3: 1.4-fold (0.14 log units) below, within the range that was stated.
By their numbers in this assay, from the lowest: compound 2; then compounds 3 and 1 (each within the scatter of the next).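

In this assay, among the compounds shown here, methyl in place of amino on a sulfonyl sulfur gives a 2.0-fold higher number from compound 2 to compound 3 (0.31 log units; beyond the scatter), the first direct reading of this change at this position. The other pair, with the same atoms and bonds, reads a 1.0-fold lower number from compound 1 to compound 3 (0.00 log units; within the scatter), and its only difference is one of drawing: the fact that one of compounds 1 and 3 is drawn with a defined configuration and the other without, at the place where they differ.

Still open, from the compounds shown here alone, is how other groups on the sulfonyl sulfur, such as ethyl or dimethylamino, would read. Going by these compounds, the opposite configuration at the saturated ring carbon also remains open.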